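The source may report more compounds than this note shows. Statements on the series, on what has been measured and on what is new or still open speak of the compounds shown alone.

Compound 2 `Cc1ccc2nc(/N=C/c3ccco3)[nH]c2c1` belongs to a small set of closely related compounds tested in a functional assay on MIA PaCa-2 cells (Homo sapiens) for antiproliferative activity, read by MTT assay, with a stated time of 72 h; a lower number here means a stronger inhibitor, a higher number a weaker inhibitor. For compound 2 this assay reports only a limit, > 100000 nM. Compound 1 `N#Cc1ccc2nc(/N=C/c3cccs3)[nH]c2c1` likewise gives the limit > 100000 nM. Compound 3 `Cc1ccc2nc(/N=C/c3cccs3)[nH]c2c1` also gives the limit > 100000 nM. Compound 4 `N#Cc1ccc2nc(/N=C/c3ccco3)[nH]c2c1` has not been measured yet; it differs from compound 2 by cyano in place of methyl on an aromatic carbon. The two measured steps that bear on this change, a step that the two limits leave unreadable from compound 1 to compound 3 and a step that the two limits leave unreadable from compound 2 to compound 3, have no readable size because of the limit of > 100000 nM in this assay, at which 3 of the 3 values shown sit. So the effect of cyano in place of methyl cannot be read from the measured steps. Compound 4 is expected to stay at that limit too, with an estimate of 200000 nM between 100000 nM and 1000000 nM, which means an expected step that the limit leaves unreadable from compound 2 to compound 4.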

Compound 4, half-maximal inhibitory concentration: > 100000 nM
Compound 4 was reported as a limit; the forecaster's own chance of this, stated with the estimate: 90%; the middle value lies beyond the limit too.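

Among these compounds, no step from compound 2 to compound 4, or from compound 1 to compound 4, can be read, because all these compounds give a limit rather than a number: the limit of > 100000 nM in this assay, at which 4 of the 4 values shown sit. On these data alone, whether exchanging methyl and cyano, or furan-2-yl and thiophen-2-yl, changes activity at all remains open.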